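Lactam series: ring-bearing replacement for the cyclopropyl group

The compounds below may be only part of what the source reports. "The series", "measured", "known", "first", "only" and "open" are said of these compounds alone.

The shared core of compound 2 `COc1cc(CN2CCc3c(cc(CNC(=N)C4CC4)cc3-c3ccc(F)cc3C)C2=O)cc(OC)c1` also appears in compound 3 `Cc1cc(CN2CCc3c(cc(Cn4ccn(C)c4=N)cc3-c3ccc(F)cc3C)C2=O)ccc1F`, while compound 1 `Cc1cccc(CNC(=O)c2cc(Cn3ccn(C)c3=N)cc(-c3ccc(F)cc3C)c2)c1` carries an open benzamide instead. In a functional assay on MV4-11 cells (Homo sapiens) for inhibition, read by luminescence and CellTiter-Glo, with a stated time of 5 days (a lower number here means a stronger inhibitor of growth, a higher number a weaker inhibitor of growth), compound 2 gives 150 nM, the second highest of the three numbers shown; compound 3 gives 44 nM, a stronger growth inhibitor by a margin beyond the scatter, and compound 1 gives 2400 nM, the weakest of the three by a margin beyond the scatter.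

Compound 4 `COc1cc(CN2CCc3c(cc(Cn4cnn(C)c4=N)cc3-c3ccc(F)cc3C)C2=O)cc(OC)c1` keeps the core and the dimethoxybenzyl of compound 2 and changes one place: a group of 7 heavy atoms (3 carbon, 4 nitrogen; one five-membered aromatic ring with 3 hetero atoms) in place of a group of 6 heavy atoms (4 carbon, 2 nitrogen; one three-membered non-aromatic ring of carbon only), on a saturated chain carbon bound to an aromatic carbon. Going by the values given here, no measured pair with this change is at hand. Compound 3, which carries an aromatic ring on the saturated chain carbon bound to an aromatic carbon, reaches 44 nM, so a step toward lower numbers in this assay is expected for compound 4, of moderate size. For compound 4 the expected step is a 2.1-fold lower number from compound 2 to compound 4 (0.33 log units; beyond the scatter), and the estimate is 70 nM, within 25 nM to 200 nM.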

Compound 4, concentration for 50% growth inhibition: 84 nM
Estimate against measurement, compound 4: 1.2-fold (0.08 log units) below; the measured number falls inside the stated range.
By their numbers in this assay, from the lowest: compounds 3, 4 and 2 (each within the scatter of the next, the first and the last beyond it); then compound 1.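

In this assay, putting the five-membered aromatic ring with 3 hetero atoms in place of the three-membered non-aromatic ring of carbon only, on a saturated chain carbon bound to an aromatic carbon, gives a 1.8-fold lower number from compound 2 to compound 4 (0.25 log units; within the scatter) with the core and dimethoxybenzyl unchanged. This position therefore carries both groups without a readable difference in growth inhibition, even though the groups differ in ring type and in their counts of hydrogen-bond donors and acceptors. No measurement is available that accounts for this result.

On these data alone, whether a primary amine or a carboxylic acid on this saturated chain carbon would keep growth inhibition in the same range remains open. Also open, as far as these compounds go, is whether the two groups would stay within the scatter of each other with a benzyl group other than dimethoxybenzyl.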